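From Phenyl to Benzoyl on a Ring Nitrogen

The compounds below may be only part of what the source reports. "The series", "measured", "known", "first", "only" and "open" are said of these compounds alone.

Of the compounds shown here, two built on one shared core have been measured in an assay on tissue (HeLa cells) for inhibition of Indoleamine 2,3-dioxygenase 1 (Homo sapiens), with a stated time of 48 h; on this read-out lower numbers stand for stronger inhibition and higher numbers for weaker inhibition. Compound 1 `O=C(/C(=N/O)Nc1ccc(F)c(Br)c1)C1CCN(C(=O)NCc2ccccc2)CC1` gives 28 nM in this assay, while compound 2 `O=C(/C(=N/O)Nc1ccc(F)c(Br)c1)C1CCN(c2ccccc2)CC1` gives 1020 nM. Going by the values given here, compound 2 therefore stands at the higher of the two numbers, and the single step joining them, a 36-fold higher number from compound 1 to compound 2 (1.56 log units; beyond the scatter), was large and clearly beyond the scatter.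

Compound 3 `O=C(/C(=N/O)Nc1ccc(F)c(Br)c1)C1CCN(C(=O)c2ccccc2)CC1` has not yet been measured. It differs from compound 2 in one place: benzoyl in place of phenyl on an amine nitrogen in a ring. Among the compounds with values here, only one measured step bears on this change, a 36-fold higher number from compound 1 to compound 2 (1.56 log units; beyond the scatter), in which a benzylcarbamoyl group carrying a carbonyl gave way to a bare phenyl and the number rose sharply. Compound 3 puts a carbonyl back on the same ring nitrogen, now within a benzoyl group rather than a benzylcarbamoyl, so a move in the opposite direction is expected, though not necessarily to the full extent seen with compound 1. The step expected for compound 3 is a 10-fold lower number from compound 2 to compound 3 (1.01 log units; beyond the scatter). Compound 3 is thus estimated at 100 nM in this assay, within a range from 25 nM to 400 nM.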

Compound 3, half-maximal inhibitory concentration: 281 nM
For compound 3 the middle estimate is 2.8-fold (0.45 log units) below the measured one; low and high end bracket the measured number.
By their numbers in this assay, from the lowest: compound 1; then compound 3; then compound 2.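

In this assay the change from phenyl to benzoyl on the amine nitrogen in a ring gives a 3.6-fold lower number from compound 2 to compound 3 (0.56 log units; beyond the scatter) and so shows that this position also responds to a group smaller than benzylcarbamoyl. The benzoyl group does not reach the level of compound 1, however: phenyl in place of benzylamino on a carbonyl carbon gives a 10-fold higher number from compound 1 to compound 3 (1.00 log units; beyond the scatter) even though the carbonyl stays in place, so the carbonyl on the ring nitrogen does not alone set the number, and the group attached to it matters as well. Nothing available here explains either step.

On these data alone, whether the difference between compound 1 and compound 3 follows from the linking nitrogen of the benzylamino group or from its extra carbon remains open, and a phenylacetyl group on the ring nitrogen would bear on that question. As far as these compounds go, how far the number depends on the terminal phenyl ring also remains open, and a methylamino group on the same carbonyl carbon would address this.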